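The source may hold more compounds than are shown below. What is called first, only, known or untested is meant among the compounds shown, and "the series" means these compounds.

Measured so far in an assay on RBL cells for inhibition of Polyunsaturated fatty acid 5-lipoxygenase (Rattus norvegicus); a lower number here means a stronger inhibitor, a higher number a weaker inhibitor:

compound 1 `CC(c1ccc2oc(-c3ccccc3)cc2c1)N(O)C(=O)c1ccccc1`: 4830 nM
compound 2 `CC(c1ccc2oc(-c3ccccc3)cc2c1)N(O)C(=O)c1ccco1`: 40 nM
compound 3 `COC(=O)CCCC(=O)N(O)C(C)c1ccc2oc(-c3ccccc3)cc2c1`: 60 nM

Compound 3 stands second highest of the three numbers in this assay. Its nearest neighbour is compound 2, with a 1.5-fold higher number from compound 2 to compound 3 (0.18 log units; within the scatter), a gap within the scatter, so the two cannot be ordered. Its furthest neighbour is compound 1, with an 81-fold lower number from compound 1 to compound 3 (1.91 log units; beyond the scatter), a large step.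

Compound 4 `CC(c1ccc2oc(-c3ccccc3)cc2c1)N(O)C(N)=O` differs from compound 3 by amino in place of 3-(methoxycarbonyl)propyl on a carbonyl carbon. The place is the same carbonyl carbon at which all three measured compounds differ from one another. Among the compounds with values here, two measured steps bear on this position: a 120-fold lower number from compound 1 to compound 2 (2.08 log units; beyond the scatter) and an 81-fold lower number from compound 1 to compound 3 (1.91 log units; beyond the scatter), both large, showing that the group on this carbonyl carbon can move the number a long way. Against that, a 1.5-fold higher number from compound 2 to compound 3 (0.18 log units; within the scatter) shows that two quite different groups here give numbers within the scatter of each other. Within the data shown here, no measured compound carries an amino at this position, so the direction of the step from compound 3 to compound 4 is not fixed by the data; a step of moderate size in this assay, a 2.0-fold higher number from compound 3 to compound 4 (0.30 log units; within the scatter), is expected rather than a large one. Compound 4 is estimated at 120 nM, with a range from 25 nM to 600 nM.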

Compound 4, half-maximal inhibitory concentration: 410 nM
Compound 4: the middle estimate sits 3.4-fold (0.53 log units) below what was measured; measured number inside the range.
By their numbers in this assay, from the lowest: compounds 2 and 3 (each within the scatter of the next); then compound 4; then compound 1.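

In this assay, amino gives this carbonyl carbon a third level of number: a 6.8-fold higher number from compound 3 to compound 4 (0.83 log units; beyond the scatter) and a 10-fold higher number from compound 2 to compound 4 (1.01 log units; beyond the scatter) place it clear of the two groups that could not be ordered, while a 12-fold lower number from compound 1 to compound 4 (1.07 log units; beyond the scatter) also places it clear of phenyl. The order among these four groups does not follow size alone, as amino, the smallest, falls between phenyl and the pair of furan-2-yl and 3-(methoxycarbonyl)propyl, and amino is also the only one of the four with a hydrogen-bond donor, so this series cannot separate the two features. Nothing measured here accounts for any of these steps.

On these data alone, it remains open whether a methylamino or dimethylamino group on this carbonyl carbon would stay close to compound 4 or move towards compound 2 and compound 3, which would help separate the presence of the donor from the size of the group. Also open, as far as these compounds go, is whether a carboxylic acid in place of the methyl ester, or a shorter chain, would keep the number of compound 3, and whether a thiophene ring would follow furan-2-yl or phenyl.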